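Benzoxazole anilides: chloro removal in the second pair

The source may hold more compounds than are shown below. What is called first, only, known or untested is meant among the compounds shown, and "the series" means these compounds.

Measured so far:
compound 1, `CN(C)CCN1CCN(CC(=O)Nc2ccc(-c3nc4cc(Cl)ccc4o3)cc2)CC1`: 7920 nM
compound 2, `CN(C)CCN1CCN(CC(=O)Nc2ccc(-c3nc4ccccc4o3)cc2)CC1`: 59400 nM
compound 3, `Cc1cc(-c2nc3cc(Cl)ccc3o2)ccc1NC(=O)CN1CCN(CCCN(C)C)CC1`: 63400 nM

In a functional assay on MCF7 cells (Homo sapiens) for cytotoxicity, read by MTT assay, with a stated time of 24 h (a higher number here means a weaker inhibitor, a lower number a stronger inhibitor), compound 1 gives 7920 nM, compound 2 gives 59400 nM and compound 3 gives 63400 nM. The change from compound 1 to compound 2, (hydrogen in place of chloro on an aromatic carbon), made the step of a 7.5-fold higher number from compound 1 to compound 2 (0.88 log units; beyond the scatter). Compound 3 carries a different core; the difference between the core of compound 3 and the core of compound 1 is not broken down here. Compound 3 and compound 2 sit within the scatter of each other, while compound 3 stands beyond the scatter from compound 1.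

Compound 4, `Cc1cc(-c2nc3ccccc3o2)ccc1NC(=O)CN1CCN(CCCN(C)C)CC1`, is not yet measured. It differs from compound 3 by hydrogen in place of chloro on an aromatic carbon, the same change as from compound 1 to compound 2, since the two place descriptions read alike. For compound 4 the expected step is a 3.9-fold higher number from compound 3 to compound 4 (0.60 log units; beyond the scatter). Going by the values given here, this expectation rests on the one measured step, a 7.5-fold higher number from compound 1 to compound 2 (0.88 log units; beyond the scatter), applied to the value of compound 3, 63400 nM, and only two occurrences of the change exist. Compound 4 is estimated at 250000 nM, between 70000 nM and 900000 nM.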

Compound 4, half-maximal inhibitory concentration: 11300 nM
Estimate against measurement, compound 4: 22-fold (1.34 log units) above; measured number outside the range, below it.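

In this assay hydrogen in place of chloro gives a 5.6-fold lower number from compound 3 to compound 4 (0.75 log units; beyond the scatter) and thus runs opposite to the step seen on the core of compound 1. The two occurrences of the change disagree in direction, not only in size: the same change on two cores in this assay, a 7.5-fold higher number (0.88 log units; beyond the scatter) from compound 1 to compound 2 and a 5.6-fold lower number (0.75 log units; beyond the scatter) from compound 3 to compound 4, 42-fold (1.62 log units) apart, beyond the scatter of two such steps. On these two pairs the outcome of the change depends on the core, and a step measured on one core gives no usable forecast for the other; the pairs do not show which structural feature is responsible, and two occurrences set no rule for the wider series.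

Which part of the difference between the core of compound 1 and the core of compound 3 turns the step around stays open, as does whether either direction would recur on a third core. Also open, as far as these compounds go, is how fluoro, bromo or methoxy in the place of chloro would behave on each of the two cores.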